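Toluenesulfonyloxy Replacing Phenylethylamino on a Shared Core

The source may report more compounds than this note shows. Statements on the series, on what has been measured and on what is new or still open speak of the compounds shown alone.

The series is built on one shared core. Among the compounds with values here, compound 1, `CS(=O)(=O)Oc1c(C(=O)NCc2ccc(F)cc2)nc(Br)c2cccnc12`, is the only member with a number in a toxicity assay on C8166 cells (Homo sapiens) for cytotoxicity, read by MTT assay, with a stated time of 72 h; on this read-out higher numbers stand for lower toxicity in this test and lower numbers for higher toxicity in this test: compound 1 gives 48000 nM. Compound 2, `NCCNc1c(C(=O)NCc2ccc(F)cc2)nc(Br)c2cccnc12`, has no result in this assay, with "not determined" (no result reported) reported. Compound 3, `C[C@H](Nc1c(C(=O)NCc2ccc(F)cc2)nc(Br)c2cccnc12)c1ccccc1`, likewise stands without a number in this assay, with "not determined" (no result reported) reported, so nothing measured places compound 3 relative to compound 1 here.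

Compound 4, `Cc1ccc(S(=O)(=O)Oc2c(C(=O)NCc3ccc(F)cc3)nc(Br)c3cccnc23)cc1`, has not yet been tested in this assay. It differs from compound 3 in one place: ((4-methylphenyl)sulfonyl)oxy in place of (1-phenylethyl)amino on an aromatic carbon. The change removes the only hydrogen-bond donor of that group and the single defined stereocentre, and brings in the two double bonds outside aromatic rings that belong to the sulfonyl group.

Within the data shown here, no measured step between two compounds is known, so no size can be given from the data. Compound 4 differs from compound 1 only in the carbon fragment attached to the sulfur, and the value of compound 1, 48000 nM, is the nearest guide. Compound 4 is therefore expected to give about 45000 nM, with a range from 15000 nM to 150000 nM.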

Compound 4, half-maximal cytotoxic concentration: 31000 nM
Compound 4: middle estimate off by 1.5-fold (0.16 log units), on the high side, within the range that was stated.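

Compound 4 gives this position a second number in this assay, and it shows that the carbon fragment on the sulfonyl sulfur can go from methyl to 4-methylphenyl with only a 1.5-fold lower number from compound 1 to compound 4 (0.19 log units; within the scatter), so the read-out does not separate these two groups. Within the data shown here, compound 3 stands without a number, so no step that involves it, or compound 2, can be read, and the swap of (1-phenylethyl)amino for ((4-methylphenyl)sulfonyl)oxy remains without a size. Nothing available explains the result of this change.

Still open, from the compounds shown here alone, is how a hydroxyl group or a methoxy group on this aromatic carbon would read against the two sulfonyl compounds. Also open, going by these compounds, is whether a carboxylic acid on the phenyl ring, or a longer alkyl chain on the sulfur, would leave the number where these two compounds put it.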